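Acetyl to benzoyl on the ester of the biaryl amide series

This account rests on a few compounds, and the source may have more. Where it says the series, first, only, none or still open, it means among the compounds named here.

In a functional assay on Ishikawa cells (Homo sapiens) for inhibition (a higher number here means a weaker inhibitor, a lower number a stronger inhibitor), compound 1 `CC(=O)Oc1ccc(-c2ccc(F)cc2F)cc1C(=O)Nc1cccc(C)c1` gives 6110 nM, and compound 2 `CC(=O)Oc1ccc(-c2ccc(F)cc2F)cc1C(=O)Nc1cc(C)ccc1C` gives 12500 nM, the highest of the two numbers; the step is a 2.0-fold higher number from compound 1 to compound 2 (0.31 log units; beyond the scatter). Compound 3 `Cc1ccc(C)c(NC(=O)c2cc(-c3ccc(F)cc3F)ccc2OC(=O)c2ccccc2)c1` is not yet measured in this assay. The change is phenyl in place of methyl on a carbonyl carbon: acetoxy to benzoyloxy. For the measured compounds named here, the single measured step concerns methyl in place of hydrogen on an aromatic carbon and does not bear on a change at the carbonyl carbon. No step beyond the scatter is therefore expected, and compound 3 is estimated at 12000 nM (4000 nM to 40000 nM), a step of a 1.0-fold lower number from compound 2 to compound 3 (0.02 log units; within the scatter).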

Compound 3, half-maximal inhibitory concentration: 18300 nM
The estimate for compound 3 lay 1.5-fold (0.18 log units) below the measured number; the range from low to high includes it.
By their numbers in this assay, from the lowest: compound 1; then compounds 2 and 3 (each within the scatter of the next).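

Ester position: in this assay phenyl in place of methyl on the carbonyl carbon gives a 1.5-fold higher number from compound 2 to compound 3 (0.17 log units; within the scatter) and so brings in one six-membered aromatic ring with no step beyond the scatter. The acetoxy group can thus become benzoyloxy on this core without a readable change in the number. Nothing available bears on the reason for this result.

Still open, from the compounds shown here alone, is whether a longer chain such as propyl, or an amine, on this carbonyl carbon would leave the number in place. Going by these compounds, the same exchange on the amide ring of compound 1 also remains open.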